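Second chloro on the benzyl ring of compound 2

The source may report more compounds than this note shows. Statements on the series, on what has been measured and on what is new or still open speak of the compounds shown alone.

Measured so far:
compound 1 `CC(C)(N)C(=O)N[C@H](COCc1ccc(F)cc1F)c1nnnn1CCOC(=O)NCCCCO` — 0.42 nM
compound 2 `CC(C)(N)C(=O)N[C@H](COCc1cccc(Cl)c1)c1nnnn1CCOC(=O)NCCCCO` — 1.6 nM

Going by the values given here, in a functional assay on cells for inhibition of growth hormone secretagogue receptor type 1 (Homo sapiens), read by FLIPR and calcium flux (a lower number here means that less compound is needed, a higher number that more compound is needed for the effect), compound 2 gives 1.6 nM, the higher of the two numbers; the only neighbour is compound 1, which gives 0.42 nM. Among the compounds with values here, the single measured step, a 3.8-fold higher number from compound 1 to compound 2 (0.58 log units; beyond the scatter), exchanges one halogen pattern on the benzyl ring for another and lies beyond the scatter, so the substitution pattern on that ring does register in this assay.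

Compound 3 `CC(C)(N)C(=O)N[C@H](COCc1cccc(Cl)c1Cl)c1nnnn1CCOC(=O)NCCCCO` carries chloro in place of hydrogen on an aromatic carbon. Within the data shown here, no measured step adds a substituent to this ring while keeping the rest fixed, so the step from compound 2 to compound 3 cannot be read directly off the data. The move from compound 1 to compound 2 shows only that the halogen pattern matters, not in which direction a second chloro will act; a step of modest size in either direction, or none beyond the scatter, is plausible. Compound 3 is therefore expected near compound 2, with a 1.6-fold lower number from compound 2 to compound 3 (0.20 log units; within the scatter), at an estimated 1 nM, range 0.3 nM to 3.5 nM.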

Compound 3, half-maximal effective concentration: 0.61 nM
Beside the measured number, compound 3's estimate is 1.6-fold (0.21 log units) above it; the range from low to high includes it.
By their numbers in this assay, from the lowest: compounds 1 and 3 (each within the scatter of the next); then compound 2.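

In this assay a chloro entering ortho to a chloro group gives a step beyond the scatter (a 2.6-fold lower number from compound 2 to compound 3 (0.42 log units; beyond the scatter)), so a single added atom at this aromatic carbon registers, which the earlier pair, differing in a whole halogen pattern, could not show. The 2,3-dichlorophenyl and 2,4-difluorophenyl groups are not separated (a 1.5-fold higher number from compound 1 to compound 3 (0.16 log units; within the scatter)), so two different two-halogen patterns give numbers within the scatter of each other. Nothing on hand accounts for the step from the 3-chlorophenyl to the 2,3-dichlorophenyl group.

On these data alone, whether the lower number depends on chloro itself remains open, since fluoro, methyl or methoxy at this carbon would test that. Also open, as far as these compounds go, is whether the 2-chlorophenyl group alone, without the existing chloro, gives the same result.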